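The source may report more compounds than this note shows. Statements on the series, on what has been measured and on what is new or still open speak of the compounds shown alone.

Compounds measured in an assay on cells for displacement of a labelled ligand from adenosine receptor A3 (Homo sapiens), read by scintillation counting and radioligand binding, with a stated time of 180 min, tested at 10 uM; on this read-out lower numbers stand for less inhibition and higher numbers for more inhibition at the one concentration tested (going by the name of the read-out):
Compound 1 `Cn1cnc2c(N3CCCCC3)nc(-c3cccc(O)c3O)nc21` gives 33.7%.
Compound 2 `Clc1ccc(-c2nc(N3CCCCC3)c3nc[nH]c3n2)cc1Cl` gives > 80%, which is a limit of the assay and not a number.
Compound 3 `Clc1ccc(-c2nc(N3CCCCC3)c3nc[nH]c3n2)cc1` gives > 80%, likewise a limit of the assay.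

Among the measured compounds shown here, compound 1 stands as the only actual number among the three values; the other two sit at the limit, which is the same limit where two of the three results rest (the limit of > 80% in this assay, at which 2 of the 3 values shown sit). For the measured compounds named here, the single measured step, a step that the two limits leave unreadable from compound 2 to compound 3, runs from one limit to the other and so its size cannot be read. Compound 4 `Cn1cnc2c(N3CCCCC3)nc(-c3cccc(Cl)c3)nc21` is not yet measured; it differs from compound 1 by 3-chlorophenyl in place of 2,3-dihydroxyphenyl on an aromatic carbon. Going by the values given here, no measured step bears directly on this change, and the core shared by compound 1 and compound 4 is not the core of compound 2 and compound 3. Still, compound 2 and compound 3, which carry chlorine-bearing phenyl groups, both sit at the limit of the assay. Compound 1 with its 2,3-dihydroxyphenyl gives 33.7%. Compound 4 is therefore expected to show a rise, a number 31.3 percentage points higher from compound 1 to compound 4 (beyond the scatter), beyond the scatter. Compound 4 is estimated at 65%, within 40% to 85%.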

Compound 4, a percentage reported as inhibition, at one concentration (the size of the read-out at that concentration, not a potency): 6.1%
The estimate for compound 4 lay 58.9 percentage points above the measured number, outside the stated range (below it).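

In this assay, this aromatic carbon between two ring nitrogen atoms gives the first readable change among the compounds shown: 3-chlorophenyl in place of 2,3-dihydroxyphenyl brings a number 27.6 percentage points lower from compound 1 to compound 4 (beyond the scatter). On the core of compound 1, then, a chlorine-bearing phenyl group does not give a reading at the limit of the assay, and the swap removes the hydrogen-bond donors and acceptors of the group that leaves. Nothing shown gives a cause for this step.

The step between the two values that are limits of the assay cannot be read. Among the compounds shown here, the single change removes both hydroxyl groups and adds chlorine, so their separate shares stay open, and 3-hydroxyphenyl or unsubstituted phenyl on the same core would be the groups to tell them apart.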